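Methylating the Piperazine Nitrogen of Compound 1

The compounds below may be only part of what the source reports. "The series", "measured", "known", "first", "only" and "open" are said of these compounds alone.

Going by the values given here, compound 1 `CNc1ncc2c(-c3ccc(N4CCNCC4)nc3)nn(Cc3cn(Cc4ccccc4)nn3)c2n1` is one of two compounds measured in an assay for inhibition of tyrosine-protein kinase receptor UFO (Homo sapiens), read by 33P incorporation, in the presence of a further agent that is not named here; on this read-out lower numbers stand for stronger inhibition and higher numbers for weaker inhibition. In this assay compound 1 gives 400 nM, the lower of the two numbers. Compound 2 `CNc1ncc2c(-c3ccc(N4CCNCC4)nc3)nn(Cc3cn(-c4ccsc4C(=O)OC)nn3)c2n1`, which carries 2-(methoxycarbonyl)thiophen-3-yl in place of benzyl on an aromatic nitrogen, gives 780 nM in this assay, and the step of a 2.0-fold higher number from compound 1 to compound 2 (0.29 log units; within the scatter) stays within the scatter. Compound 3 `CNc1ncc2c(-c3ccc(N4CCN(C)CC4)nc3)nn(Cc3cn(Cc4ccccc4)nn3)c2n1` differs from compound 1 elsewhere: methyl in place of hydrogen on an amine nitrogen in a ring, so that piperazin-1-yl becomes 4-methylpiperazin-1-yl. Among the compounds with values here, no measured step touches this amine nitrogen; the only step in hand, from compound 1 to compound 2, concerns another part of the molecule and was itself within the scatter. There is thus no ground for expecting a step beyond the scatter in this assay, in either direction. Compound 3 is accordingly expected to give about 400 nM in this assay, within a range from 150 nM to 1100 nM, an expected step of no change at the digits printed from compound 1 to compound 3 (within the scatter).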

Compound 3, half-maximal inhibitory concentration: 380 nM
The estimate for compound 3 lay 1.1-fold (0.02 log units) above the measured number, within the range that was stated.
By their numbers in this assay, from the lowest: compounds 3, 1 and 2 (each within the scatter of the next, the first and the last beyond it).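

Going by these compounds alone, the step at this amine nitrogen in the ring, a 1.1-fold lower number from compound 1 to compound 3 (0.02 log units; within the scatter), is the first reading at a position that the earlier step, made on the other side of the molecule, did not touch. In this assay the hydrogen on this nitrogen is thus not needed to keep the number seen with compound 1, since 4-methylpiperazin-1-yl in compound 3 stays within the scatter of piperazin-1-yl. Nothing at hand accounts for this result.

The compounds shown leave open whether a group larger than methyl on this nitrogen, such as an acetyl, a 2-hydroxyethyl or a longer chain, would also stay within the scatter. They also leave open whether methyl here would read the same alongside the 2-(methoxycarbonyl)thiophen-3-yl group of compound 2.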